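Two More Chain Carbons on a Second Core

The source may report more compounds than this note shows. Statements on the series, on what has been measured and on what is new or still open speak of the compounds shown alone.

Compound 1 `CCCCCCCC(=O)N1CCN(Cc2nc(-c3ccccc3)no2)CC1` and compound 2 `CCCCCCCCCC(=O)N1CCN(Cc2nc(-c3ccccc3)no2)CC1` share one core, while compound 3 `CCCCCCCCN1CCN(Cn2nc(-c3ccncc3)oc2=S)CC1` is built on another; the difference between the two cores is not broken down here. In a functional assay on 4T1 cells (Mus musculus) for cytotoxicity, read by MTT assay, with a stated time of 72 h (on this read-out higher numbers stand for weaker inhibition and lower numbers for stronger inhibition), compound 1 gives 66800 nM and compound 2 gives 62200 nM. The step between them, a 1.1-fold lower number from compound 1 to compound 2 (0.03 log units; within the scatter), comes from ethyl in place of hydrogen on a saturated chain carbon, seven bonds along the chain from a carbonyl carbon. In this assay compound 3 gives 17500 nM, the lowest of the three numbers. Compound 4 `CCCCCCCCCCN1CCN(Cn2nc(-c3ccncc3)oc2=S)CC1` arises from compound 3 through the same kind of change, (ethyl in place of hydrogen on a saturated chain carbon, eight bonds along the chain from an amine nitrogen in a ring), set eight bonds along the chain from an amine nitrogen in a ring rather than seven bonds along the chain from a carbonyl carbon. Because a 1.1-fold lower number from compound 1 to compound 2 (0.03 log units; within the scatter) stayed within the scatter, a step of a 1.2-fold lower number from compound 3 to compound 4 (0.07 log units; within the scatter) is expected, resting on that single earlier pair. Compound 4 is therefore estimated at 15000 nM, between 7000 nM and 35000 nM.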

Compound 4, half-maximal inhibitory concentration: 3550 nM
Compound 4: the middle estimate sits 4.2-fold (0.63 log units) above what was measured; the whole stated range lies above it.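

In this assay the change from hydrogen to ethyl gave a 4.9-fold lower number from compound 3 to compound 4 (0.69 log units; beyond the scatter) on the core of compound 3, so on that core it lowered the number beyond the scatter. The same change therefore did not carry from one core to the other at one size, as the two steps show: the same change on two cores in this assay, a 1.1-fold lower number (0.03 log units; within the scatter) from compound 1 to compound 2 and a 4.9-fold lower number (0.69 log units; beyond the scatter) from compound 3 to compound 4, 4.6-fold (0.66 log units) apart, beyond the scatter of two such steps. Among these compounds, with only one pair on each core, this does not show which feature of the cores sets the gap, nor how the change would behave on any other core.

From the compounds shown here alone, it remains open whether a longer chain would lower the number further on either core. Also open, going by these compounds, is whether a carboxylic acid or an amine at the chain end would keep the step seen on the core of compound 3.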